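Isopropyl to cyclopropyl on the shared core

A few compounds are considered here, and "the series" means these few. Any claim that something is new, unique, unknown or untested is made for them only; others in the source may bear on it.

The series is followed in an ADME assay on microsomes from liver (Mus musculus) for metabolic stability, with a stated time of 30 min; a lower number here means that less of the compound is left, a higher number that more of the compound is left. Among the measured compounds shown here, compound 1 `CCCCc1nc(C(C)C)c(CC(=O)OC)c(=O)n1Cc1ccc(-c2ccccc2-c2noc(=O)[nH]2)cc1` gives 9.4% in this assay, the only number in hand, and it marks a compound of which little survives the incubation. Compound 2 `CCCCc1nc(C(C)C)c(CC(=O)OCC(F)(F)F)c(=O)n1Cc1ccc(-c2ccccc2-c2noc(=O)[nH]2)cc1` carries a trifluoroethyl ester in place of the methyl ester of compound 1, but in this assay compound 2 has "not determined" (no result reported), so it adds nothing to the picture. Compound 3 `CCCCc1nc(C2CC2)c(CC(=O)OC)c(=O)n1Cc1ccc(-c2ccccc2-c2noc(=O)[nH]2)cc1` differs from compound 1 in one place: cyclopropyl in place of isopropyl on an aromatic carbon. For the measured compounds named here, no step between two measured compounds is available to calibrate this change, and nothing in the data points in either direction. A step from compound 1 to compound 3 of a number 5.6 percentage points higher from compound 1 to compound 3 (within the scatter) is expected, which is small and would lie within the usual scatter. For compound 3 a value of 15% is estimated, with a range from 4% to 35%.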

Compound 3, percent of the compound remaining: 16.4%
The estimate for compound 3 lay 1.4 percentage points below the measured number; measured number inside the range.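

In this assay, cyclopropyl in place of isopropyl on an aromatic carbon gives a number 7 percentage points higher from compound 1 to compound 3 (within the scatter). Among the compounds shown here, this is the first step that can be read, and it shows that this position, opposite the ring nitrogen, takes a three-membered carbon ring in place of isopropyl with no difference beyond the scatter. No supporting measurement bears on this result, so the step stands without any explanation.

Still open, from the compounds shown here alone, is whether a different group at this position, such as an amine or a longer chain, would give a step beyond the scatter. Also open, going by these compounds, is how the read-out responds at other places on the shared core, for example with a carboxylic acid in place of the methyl ester, which compound 1 and compound 3 both carry.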